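The compounds below may be only part of what the source reports. "The series", "measured", "known", "first", "only" and "open" are said of these compounds alone.

Values so far in a functional assay on HSC-4 cells (Homo sapiens) for cytotoxicity, with a stated time of 24 h; on this read-out lower numbers stand for higher toxicity in this test and higher numbers for lower toxicity in this test
- compound 1 `O=C1/C(=C/c2ccc(F)cc2)CCC/C1=C\c1ccc([N+](=O)[O-])cc1` at 15000 nM
- compound 2 `O=C1/C(=C/c2ccc(Cl)cc2)CCC/C1=C\c1ccc([N+](=O)[O-])cc1` at 2700 nM

Within the data shown here, compound 2 stands lowest of the two at 2700 nM in this assay so far. Compound 3 `Cc1ccc(/C=C2\CCC/C(=C\c3ccc([N+](=O)[O-])cc3)C2=O)cc1` has methyl in place of chloro on an aromatic carbon, para to a large group (methyl in place of chloro on an aromatic carbon). Among the measured compounds shown here, the only measured step bearing on this is chloro in place of fluoro on an aromatic carbon, a 5.6-fold lower number from compound 1 to compound 2 (0.74 log units; beyond the scatter) and modest in size. For the measured compounds named here, no measured compound carries methyl, so this guide is indirect. A modest move towards a higher number is expected, with the estimated step of a 2.2-fold higher number from compound 2 to compound 3 (0.35 log units; beyond the scatter) in this assay overall. For compound 3 the estimated value is 6000 nM with an expected range of 2000 nM to 18000 nM here.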

Compound 3, half-maximal cytotoxic concentration: 13000 nM
Compound 3: middle estimate off by 2.2-fold (0.34 log units), on the low side; the range from low to high includes it.
By their numbers in this assay, from the lowest: compound 2; then compounds 3 and 1 (each within the scatter of the next).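

In this assay, the lower number at this position does not carry over from chloro to methyl (a 4.8-fold higher number from compound 2 to compound 3 (0.68 log units; beyond the scatter)). Methyl and fluoro cannot be told apart (a 1.2-fold lower number from compound 1 to compound 3 (0.06 log units; within the scatter)), so among these three groups, chloro alone stands apart. Nothing available here offers a reason for this.

As far as these compounds go, whether bromo, methoxy or an amine at this position would group with chloro or with fluoro and methyl remains open. Also open, from the compounds shown here alone, is whether chloro would still stand apart if the nitro group were replaced.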